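Shifting the Methyl Within the Saturated Ring

The source may report more compounds than this note shows. Statements on the series, on what has been measured and on what is new or still open speak of the compounds shown alone.

Measured compounds:
- compound 1 `COc1cc2c(Nc3nc4ccc(C(=O)Nc5c(C)cccc5Cl)cc4s3)ncnc2cc1OCCCN1CCC(C)CC1`: 7900 nM
- compound 2 `COc1cc2c(Nc3nc4ccc(C(=O)Nc5c(C)cccc5C)cc4s3)ncnc2cc1OCCCN1CCC(C)CC1`: 72300 nM
- compound 3 `COc1cc2c(Nc3nc4ccc(C(=O)Nc5c(C)cccc5C)cc4s3)ncnc2cc1OCCCN1CCCC1`: the assay gives only a limit, > 100000 nM

Of the compounds shown here, three have been tested in a functional assay on NCI-H661 cells (Homo sapiens) for cytotoxicity, read by WST assay, with a stated time of 72 h; on this read-out lower numbers stand for stronger inhibition and higher numbers for weaker inhibition. Compound 1 stands lowest of the two numbers shown, and its nearest neighbour is compound 2, reached by a 9.2-fold higher number from compound 1 to compound 2 (0.96 log units; beyond the scatter), a change of the group on the aromatic carbon. For compound 3 the result is a limit, (the limit of > 100000 nM in this assay, at which 1 of the 3 values shown sits), so the step of an at least 1.3-fold higher number from compound 2 to compound 3 (0.14 log units; that floor lies within the scatter) has only a floor, and that floor lies within the scatter.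

Compound 4 `COc1cc2c(Nc3nc4ccc(C(=O)Nc5c(C)cccc5Cl)cc4s3)ncnc2cc1OCCCN1CCCCC1C` is the next compound to be measured. Its difference from compound 1 is 2-methylpiperidin-1-yl in place of 4-methylpiperidin-1-yl on a saturated chain carbon, three bonds along the chain from an oxygen on an aromatic ring. Within the data shown here, the only measured step at this place is the exchange of the saturated ring from compound 2 to compound 3, which gave no change that can be told from the scatter. A similar outcome is therefore expected here, with at most a small rise in the number: the estimate for compound 4 is 12000 nM, between 4000 nM and 40000 nM, meaning the expected step of a 1.5-fold higher number from compound 1 to compound 4 (0.18 log units; within the scatter).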

Compound 4, half-maximal inhibitory concentration: 5300 nM
Compound 4: middle estimate off by 2.3-fold (0.35 log units), on the high side, and the stated range covers the measured number.
By their numbers in this assay, from the lowest: compounds 4 and 1 (each within the scatter of the next); then compound 2. At a limit, above all of these: compound 3.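

In this assay, moving the methyl from one ring position to the other, with 4-methylpiperidin-1-yl replaced by 2-methylpiperidin-1-yl, leaves the result within the scatter (a 1.5-fold lower number from compound 1 to compound 4 (0.17 log units; within the scatter)). Among these compounds, this is the first step at this place on the saturated chain carbon with a measured number at both ends, since the earlier ring exchange ended in a limit, so the two methylpiperidine groups can be compared directly on the chloro-bearing compounds. Nothing measured here explains why the two groups cannot be told apart in this assay.

Still open, going by these compounds, is whether 3-methylpiperidin-1-yl, or a ring carrying a further hetero atom such as morpholine or piperazine, would also stay within the scatter of compound 1. Also open, on these data alone, is how pyrrolidin-1-yl behaves alongside the chloro group, and what a shorter ethyl chain in place of the propyl chain would do.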